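This account rests on a few compounds, and the source may have more. Where it says the series, first, only, none or still open, it means among the compounds named here.

Compound 1 `Cn1c(SCc2ccc(Cl)cc2)nnc1-c1cc([N+](=O)[O-])cc([N+](=O)[O-])c1` and compound 2 `Cn1c(SCc2ccc(Cl)c(Cl)c2)nnc1-c1cc([N+](=O)[O-])cc([N+](=O)[O-])c1` share one core, while compound 3 `O=[N+]([O-])c1cc(-c2nnc(SCc3ccc(Cl)cc3)n2Cc2ccccc2)cc(C(F)(F)F)c1` and compound 4 `O=[N+]([O-])c1cc(-c2nnc(SCc3ccc(Cl)c(Cl)c3)n2Cc2ccccc2)cc(C(F)(F)F)c1` share another; the difference between the two cores is not broken down here. In an ADME assay on A-431 cells (Homo sapiens) for cytotoxicity, with a stated time of 48 h (on this read-out lower numbers stand for stronger inhibition and higher numbers for weaker inhibition), compound 1 gives only a limit of the assay, > 30000 nM. In this assay compound 2 likewise gives a limit, > 30000 nM. In this assay compound 3 also gives a limit, > 30000 nM. The change from compound 1 to compound 2 is chloro in place of hydrogen on an aromatic carbon, and the step it made is a step that the two limits leave unreadable from compound 1 to compound 2. Compound 4 carries the same change from compound 3, (chloro in place of hydrogen on an aromatic carbon). Because the limit of > 30000 nM in this assay, at which 3 of the 3 values shown sit, holds every value shown, the effect of this change is unreadable, and the expected step is a step that the limit leaves unreadable from compound 3 to compound 4. Compound 4 is therefore estimated at 40000 nM, most probably again reported as a limit.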

Compound 4, half-maximal inhibitory concentration: > 30000 nM
Compound 4: no number, only a limit (the forecaster's own chance of this, stated with the estimate: 85%); the middle value lies beyond the limit too.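

No step can be read from compound 3 to compound 4, since compound 4 also gives only a limit, and so does every other compound: the limit of > 30000 nM in this assay, at which 4 of the 4 values shown sit.

As far as these compounds go, whether the added chloro or the change of core alters cytotoxicity in this assay stays open.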